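Adding a third methoxy group to the shared core

The source may hold more compounds than are shown below. What is called first, only, known or untested is meant among the compounds shown, and "the series" means these compounds.

Compound 1, `COc1ccc(/C=C/C(=O)c2sc(NC(=O)c3ccccc3)nc2C)cc1`, gives 58.8% in an assay for inhibition of Polyunsaturated fatty acid 5-lipoxygenase (Homo sapiens), read by spectrophotometry, tested at 10 uM, in the presence of a further agent that is not named here; a lower number here means less inhibition, a higher number more inhibition at the concentration tested (going by the name of the read-out).
Compound 2, `COc1ccc(/C=C/C(=O)c2sc(NC(=O)c3ccccc3)nc2C)cc1OC`, gives 70.2% in this assay.

Compound 2 stands highest of the two measured compounds in this assay, and its nearest neighbour is compound 1, whose number is lower by a step that lies beyond the usual scatter.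

Compound 3, `COc1cc(/C=C/C(=O)c2sc(NC(=O)c3ccccc3)nc2C)cc(OC)c1OC`, has not yet been measured. It differs from compound 2 in one place: methoxy in place of hydrogen on an aromatic carbon.

Among the measured compounds shown here, one measured step bears on this change. Going from compound 1 to compound 2 was itself a methoxy in place of hydrogen on an aromatic carbon of the same ring, and it gave a number 11.4 percentage points higher from compound 1 to compound 2 (beyond the scatter). Whether a further methoxy on that ring repeats the gain, adds nothing beyond the scatter, or turns the number downward cannot be told from two compounds alone. The expectation is therefore a step of a number 3.8 percentage points higher from compound 2 to compound 3 (within the scatter), a small increase that may well fall inside the scatter.

Compound 3 is estimated to give 74% in this assay, with a plausible range from 58% to 88%.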

Compound 3, a percentage reported as inhibition, at one concentration (the size of the read-out at that concentration, not a potency): 100%
For compound 3 the middle estimate is 26 percentage points below the measured one; measured number outside the range, above it.
By their numbers in this assay, from the lowest: compound 1; then compound 2; then compound 3.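

In this assay, the new methoxy group, placed ortho to a methoxy group and meta to a large group, gives a number 29.8 percentage points higher from compound 2 to compound 3 (beyond the scatter) and so shows that this ring, already carrying two methoxy groups, still responds to one more. Across compound 1, compound 2 and compound 3, each single added methoxy group raises the number beyond the scatter, no compound shown goes against this, and by the printed numbers the second step is the larger, so the first gain did not fade with the next addition. Nothing measured here explains why this methoxy group brings so large a step.

Still open, on these data alone, is whether a methoxy group at this place would bring a gain without the other two, and whether another group there, such as a hydroxy group, an ethoxy group or an amine, would do as well. As far as these compounds go, the read-out is also taken at a single concentration, so it gives the size of the inhibition there, and how compound 3 compares with compound 2 in potency remains unknown.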